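A few compounds are considered here, and "the series" means these few. Any claim that something is new, unique, unknown or untested is made for them only; others in the source may bear on it.

In an ADME assay on microsomes from liver (Homo sapiens) for pharmacokinetics, read by LC-MS, using NADPH, with a stated time of 30 min, tested at 1 uM (a higher number here means faster removal of the compound, a lower number slower removal), compound 1 `Cc1cc(N(C)C(N)=O)cc(C)c1CCS(=O)(=O)N1CCC2(CC1)N=C(c1ccc(OC(F)(F)F)cc1)NC2=O` gives 48 mL.min-1.g-1, compound 2 `Cc1cc(N2C(=O)CNC2=O)cc(C)c1CCS(=O)(=O)N1CCC2(CC1)N=C(c1ccc(OC(F)(F)F)cc1)NC2=O` gives 110 mL.min-1.g-1 and compound 3 `Cc1cc(N2C(=O)NC(=O)C23CCCC3)cc(C)c1CCS(=O)(=O)N1CCC2(CC1)N=C(c1ccc(OC(F)(F)F)cc1)NC2=O` gives 35 mL.min-1.g-1. Compound 3 thus stands within the scatter of compound 1 but clear of compound 2. Compound 4 `CCC1(CC)C(=O)NC(=O)N1c1cc(C)c(CCS(=O)(=O)N2CCC3(CC2)N=C(c2ccc(OC(F)(F)F)cc2)NC3=O)c(C)c1` differs from it by a group of 11 heavy atoms (7 carbon, 2 nitrogen, 2 oxygen; one five-membered non-aromatic ring with 2 hetero atoms) in place of a group of 11 heavy atoms (7 carbon, 2 nitrogen, 2 oxygen; one five-membered non-aromatic ring of carbon only, one five-membered non-aromatic ring with 2 hetero atoms), on an aromatic carbon: the five-membered non-aromatic ring of carbon only leaves, and 5,5-diethyl-2,4-dioxoimidazolidin-1-yl enters. Two measured steps change the same aromatic carbon, a 1.4-fold lower number from compound 1 to compound 3 (0.14 log units; within the scatter) and the modest 3.1-fold lower number from compound 2 to compound 3 (0.50 log units; beyond the scatter). Neither opens a ring of carbon only, so the evidence is indirect, and no shift beyond the scatter is expected in this assay. The expected change is a 1.1-fold higher number from compound 3 to compound 4 (0.04 log units; within the scatter). Compound 4 is estimated at 38 mL.min-1.g-1, with an expected range of 19 mL.min-1.g-1 to 75 mL.min-1.g-1.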

Compound 4, intrinsic clearance in microsomes: 29 mL.min-1.g-1
Estimate against measurement, compound 4: 1.3-fold (0.12 log units) above; measured number inside the range.
By their numbers in this assay, from the lowest: compounds 4, 3 and 1 (each within the scatter of the next); then compound 2.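

In this assay, replacing the carbon-only ring with two ethyl groups leaves the number within the scatter, a 1.2-fold lower number from compound 3 to compound 4 (0.08 log units; within the scatter), so this position tolerates the ring being open. The gain over the unsubstituted ring also holds, a 3.8-fold lower number from compound 2 to compound 4 (0.58 log units; beyond the scatter), though this step both adds the ethyl groups and moves from the 2,5-dioxo to the 2,4-dioxo ring. Compound 4 still does not separate from the open-chain group, a 1.7-fold lower number from compound 1 to compound 4 (0.22 log units; within the scatter). No measurement here explains these numbers. As far as these compounds go, whether plain 2,4-dioxoimidazolidin-1-yl or its 5,5-dimethyl form would show the same gain remains open.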